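A few compounds are considered here, and "the series" means these few. Any claim that something is new, unique, unknown or untested is made for them only; others in the source may bear on it.

Compound 3 `CCC1(Cc2ccccc2)OS(=O)(=O)C=C1OCc1ccc(Cl)c(Cl)c1` is one of three close relatives tested in an ADME assay on HEL cells (Homo sapiens) for cytotoxicity, with a stated time of 3 days; a higher number here means that more compound is tolerated, a lower number that less compound is tolerated. In this assay compound 3 gives only a limit of >= 20000 nM. Compound 1 `CCC1(Cc2ccccc2)OS(=O)(=O)C=C1OCc1ccc(F)cc1` likewise gives only a limit of >= 50000 nM. Compound 2 `CCC1(Cc2ccccc2)OS(=O)(=O)C=C1OC` gives only a limit of > 400000 nM. The three values sit at different limits, (the limit of > 400000 nM in this assay, at which 1 of the 3 values shown sits), the limit of >= 20000 nM in this assay, at which 1 of the 3 values shown sits, and (the limit of >= 50000 nM in this assay, at which 1 of the 3 values shown sits), so the steps between them cannot be read in size: a step that the two limits leave unreadable from compound 1 to compound 2, a step that the two limits leave unreadable from compound 1 to compound 3 and a step that the two limits leave unreadable from compound 2 to compound 3. Compound 4 `C=CCOC1=CS(=O)(=O)OC1(CC)Cc1ccccc1` has not been measured; it differs from compound 3 by vinyl in place of 3,4-dichlorophenyl on a saturated chain carbon bound to an oxygen on an unsaturated carbon. The unreadable neighbouring steps give no direction, and another limit seems the likeliest outcome. Compound 4 is expected to give about 150000 nM, between 40000 nM and 400000 nM, an estimated step that the limit leaves unreadable from compound 3 to compound 4.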

Compound 4, minimum cytotoxic concentration: 80000 nM
For compound 4 the middle estimate is 1.9-fold (0.27 log units) above the measured one; low and high end bracket the measured number.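

Among these compounds, compound 4 is the first of these relatives to give a plain number rather than a limit in this assay, so a step at this position can now be sized. On a saturated chain carbon bound to an oxygen on an unsaturated carbon, vinyl in place of hydrogen gives an at least 5.0-fold lower number from compound 2 to compound 4 (0.69 log units; beyond the scatter), so less compound is tolerated with vinyl there. The steps to compound 4 from the two aryl compounds, compound 1 and compound 3, still cannot be read.

On these data alone, whether either aryl group is tolerated better or worse than vinyl therefore stays open. So does how an amine or a carboxylic acid at this place would behave.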